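The source may hold more compounds than are shown below. What is called first, only, known or untested is meant among the compounds shown, and "the series" means these compounds.

In a functional assay on HOS cells (Homo sapiens) for antiproliferative activity, read by sulforhodamine B assay (a lower number here means a stronger inhibitor of growth, a higher number a weaker inhibitor of growth), three compounds sharing one core have been measured. Compound 1 `CCC[C@@H]1O[C@H](COCc2ccccc2)[C@@H](OCc2ccccc2)[C@H](OCc2ccccc2)[C@H]1O` gives 38600 nM, compound 2 `CCC[C@H]1O[C@H](COCc2ccccc2)[C@@H](OCc2ccccc2)[C@H](OCc2ccccc2)[C@H]1O` gives 23600 nM, and compound 3 `OC[C@@H]1O[C@H](COCc2ccccc2)[C@@H](OCc2ccccc2)[C@H](OCc2ccccc2)[C@H]1O` gives 27300 nM. Compound 3 thus lies within the scatter of both others, and the three form a single level. Compound 4 `O[C@@H]1[C@@H](OCc2ccccc2)[C@H](OCc2ccccc2)[C@@H](COCc2ccccc2)O[C@H]1Cc1ccccc1` differs from compound 3 in one place: phenyl in place of hydroxy on a saturated chain carbon bound to a saturated ring carbon. Cut one bond further out, the same difference reads hydroxymethyl to benzyl. The nearest evidence is hydroxy in place of ethyl at that same carbon, which gave a 1.4-fold lower number from compound 1 to compound 3 (0.15 log units; within the scatter). A change of configuration alone gave a 1.6-fold lower number from compound 1 to compound 2 (0.21 log units; within the scatter). Neither step goes beyond the scatter, though neither tests an aromatic ring entering there. No shift beyond the scatter is therefore expected in this assay. The expected change is a 1.1-fold lower number from compound 3 to compound 4 (0.04 log units; within the scatter). For compound 4 the estimated value is 25000 nM, with an expected range of 11000 nM to 50000 nM.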

Compound 4, concentration for 50% growth inhibition: 29200 nM
Estimate against measurement, compound 4: 1.2-fold (0.07 log units) below; the measured number falls inside the stated range.
By their numbers in this assay, from the lowest: compounds 2, 3, 4 and 1 (each within the scatter of the next).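

In this assay, an aromatic ring entering on the saturated chain carbon bound to a saturated ring carbon stays within the scatter against both neighbours: phenyl in place of hydroxy gives a 1.1-fold higher number from compound 3 to compound 4 (0.03 log units; within the scatter), and phenyl in place of ethyl gives a 1.3-fold lower number from compound 1 to compound 4 (0.12 log units; within the scatter). Until now only hydroxy and ethyl had been compared at this carbon, whereas this step adds a six-membered aromatic ring and removes the hydrogen-bond donor and acceptor of the hydroxy, and compound 4 still stays on the single level of the series. Nothing given here explains why the number holds across this change.

Going by these compounds, it remains open whether an amine, a carboxylic acid or a longer chain at this carbon would move the number in this assay beyond the scatter. On these data alone, it also remains open whether the benzyl compound would respond to a change of configuration at this ring carbon.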